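Shortening the Linker and Shifting the Nitro Group

The compounds below may be only part of what the source reports. "The series", "measured", "known", "first", "only" and "open" are said of these compounds alone.

Compound 2 `COc1cc2ncnc(Nc3ccc(F)c(Cl)c3)c2cc1OCCCCCn1ccnc1[N+](=O)[O-]` gives the highest number of the three measured in a functional assay on HT-29 cells (Homo sapiens) for cytotoxicity, read by sulforhodamine B assay, with a stated time of 72 h (a lower number here means a stronger inhibitor, a higher number a weaker inhibitor), at 17600 nM. Its nearest neighbour is compound 3 `C#Cc1cccc(Nc2ncnc3cc(OC)c(OCCCCn4ccnc4[N+](=O)[O-])cc23)c1` with 10100 nM, a gap within the scatter; furthest is compound 1 `COc1cc2ncnc(Nc3ccc(F)c(Cl)c3)c2cc1OCCCCn1ccnc1[N+](=O)[O-]` with 2210 nM, separated by an 8.0-fold higher number from compound 1 to compound 2 (0.90 log units; beyond the scatter). Compound 4 `COc1cc2ncnc(Nc3ccc(F)c(Cl)c3)c2cc1OCCn1c([N+](=O)[O-])cnc1C` differs from compound 2 by 2-methyl-5-nitro-1H-imidazol-1-yl in place of 3-(2-nitro-1H-imidazol-1-yl)propyl on a saturated chain carbon, two bonds along the chain from an oxygen on an aromatic ring. For the measured compounds named here, only the step from compound 1 to compound 2 bears on this, and it shows that lengthening the chain by one carbon raised the number; the present change shortens the chain while also moving the nitro group and adding a methyl, for which no measured step exists. A return toward compound 1, a moderate decrease in this assay, is therefore expected, a 3.5-fold lower number from compound 2 to compound 4 (0.55 log units; beyond the scatter), giving an estimate for compound 4 of 5000 nM within 1500 nM to 18000 nM.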

Compound 4, half-maximal inhibitory concentration: > 50000 nM
Compound 4: only a limit was reported; the forecaster's own chance of this, stated with the estimate: 5%; middle value at least 10-fold (1.00 log units) away from the limit.
By their numbers in this assay, from the lowest: compound 1; then compounds 3 and 2 (each within the scatter of the next). At a limit, above all of these: compound 4.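

In this assay compound 4 gave only a limit, not a number: the limit of > 50000 nM in this assay, at which 1 of the 4 values shown sits.

At this place, 2-methyl-5-nitro-1H-imidazol-1-yl on the shorter chain gave an at least 2.8-fold higher number from compound 2 to compound 4 (0.45 log units; beyond the scatter) and an at least 22-fold higher number from compound 1 to compound 4 (1.35 log units; beyond the scatter). The shorter chain therefore brought no return toward compound 1 when the ring changed with it.

The compounds shown leave open whether the chain length, the methyl or the nitro position carries this rise, since all three change together. From the compounds shown here alone, how an amine or a carboxylic acid at the chain end would read in this assay also remains open.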